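Replacing the nitrile-bearing ring in a phosphodiesterase series

The source may report more compounds than this note shows. Statements on the series, on what has been measured and on what is new or still open speak of the compounds shown alone.

Measured compounds:
- compound 1, `CCN(CC)c1ccc(NC(=O)c2cn(Cc3c(F)cccc3F)c3ccc(=O)[nH]c3c2=O)cc1`, 46 nM
- compound 2, `Nc1ccc(NC(=O)c2cn(Cc3c(F)cccc3F)c3ccc(=O)[nH]c3c2=O)cc1`, 104 nM
- compound 3, `N#Cc1cccc(NC(=O)c2cn(Cc3c(F)cccc3F)c3ccc(=O)[nH]c3c2=O)c1`, 1070 nM

All three share one core and differ only in the aromatic ring carried on the amide-type nitrogen. In an in vitro assay on Sf21 cells for inhibition of high affinity 3',5'-cyclic-AMP phosphodiesterase 7A (Homo sapiens), read by scintillation proximity assay, with a stated time of 30 min (a higher number here means a weaker inhibitor, a lower number a stronger inhibitor), compound 3 gives the highest number of the three, so it is the weakest inhibitor shown: the gap is a 10-fold higher number from compound 2 to compound 3 (1.01 log units; beyond the scatter) and a 23-fold higher number from compound 1 to compound 3 (1.37 log units; beyond the scatter), both well beyond the scatter. Compound 1 and compound 2 differ by a modest step, a 2.3-fold higher number from compound 1 to compound 2 (0.35 log units; beyond the scatter).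

Compound 4, `CS(=O)(=O)c1ccc(NC(=O)c2cn(Cc3c(F)cccc3F)c3ccc(=O)[nH]c3c2=O)cc1`, has not yet been measured in this assay. Its change from compound 3 is 4-(methylsulfonyl)phenyl in place of 3-cyanophenyl on an amide-type nitrogen. Among the measured compounds shown here, no measured pair shows this exact swap. What bears on it is that every measured step away from the 3-cyanophenyl ring, whether to 4-(diethylamino)phenyl or to 4-aminophenyl, lowered the number by a large amount. Compound 4 also leaves the 3-cyanophenyl ring and carries a 4-(methylsulfonyl)phenyl ring instead. A drop in number is therefore expected, though a smaller one than with compound 1 or compound 2, since neither measured step involves a methylsulfonyl group: the expected step is a 4.3-fold lower number from compound 3 to compound 4 (0.63 log units; beyond the scatter). Compound 4 is estimated at 250 nM, within 60 nM to 1000 nM.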

Compound 4, half-maximal inhibitory concentration: 27 nM
Beside the measured number, compound 4's estimate is 9.3-fold (0.97 log units) above it; measured number below the stated range.
By their numbers in this assay, from the lowest: compounds 4 and 1 (each within the scatter of the next); then compound 2; then compound 3.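

In this assay, the change of ring on the amide-type nitrogen gives a 40-fold lower number from compound 3 to compound 4 (1.60 log units; beyond the scatter), the largest step seen so far in this set. Until now, the two rings with low numbers both carried a nitrogen group, diethylamino or amino, but methylsulfonyl shows that a nitrogen group is not needed on this ring for a low number: a 1.7-fold lower number from compound 1 to compound 4 (0.23 log units; within the scatter), which leaves compound 1 and compound 4 within the scatter of each other, while a 3.9-fold lower number from compound 2 to compound 4 (0.59 log units; beyond the scatter) is a modest step beyond the scatter. Nothing given here offers a measured explanation for these differences.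

The step from 3-cyanophenyl to 4-(methylsulfonyl)phenyl changes both the group and the number in the ring's name, and the compounds shown do not separate what each of these contributes. Going by these compounds, it also remains open whether other groups on the aromatic carbon, such as a sulfonamide, a carboxylic acid or a morpholine, would give numbers as low as those of compound 1 and compound 4.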